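A few compounds are considered here, and "the series" means these few. Any claim that something is new, unique, unknown or untested is made for them only; others in the source may bear on it.

In a functional assay on HCT-116 cells (Homo sapiens) for inhibition, read by MTT assay, with a stated time of 48 h (on this read-out higher numbers stand for weaker inhibition and lower numbers for stronger inhibition), compound 1 (`COc1ccc(CNc2cc(OC)c(OC)c(OC)c2)cc1Br`) gives 48100 nM, compound 2 (`COC(=O)c1cc(CNc2cc(OC)c(OC)c(OC)c2)ccc1OC`) gives 38100 nM, and compound 3 (`COc1ccc(CNc2cc(OC)c(OC)c(OC)c2)cc1F`) gives 32200 nM. Compound 3 therefore stands level with the other two: a 1.5-fold lower number from compound 1 to compound 3 (0.17 log units; within the scatter) and a 1.2-fold lower number from compound 2 to compound 3 (0.07 log units; within the scatter) both lie within the scatter, as does a 1.3-fold lower number from compound 1 to compound 2 (0.10 log units; within the scatter). Compound 4 (`C/C=C/C(=O)N(Cc1ccc(OC)c(F)c1)c1cc(OC)c(OC)c(OC)c1`) differs from compound 3 elsewhere: (prop-1-en-1-yl)carbonyl in place of hydrogen on a nitrogen on an aromatic ring. The measured steps all exchange a group on an aromatic carbon, and none touches the nitrogen, so they do not gauge this change. A step beyond the scatter towards a lower number is expected, though only tentatively. The expected change is a 16-fold lower number from compound 3 to compound 4 (1.21 log units; beyond the scatter), and it is uncertain. For compound 4 the estimated value is 2000 nM, within an estimated range of 60 nM to 40000 nM.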

Compound 4, half-maximal inhibitory concentration: 1160 nM
For compound 4 the middle estimate is 1.7-fold (0.24 log units) above the measured one; measured number inside the range.
By their numbers in this assay, from the lowest: compound 4; then compounds 3, 2 and 1 (each within the scatter of the next).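

In this assay, the nitrogen on an aromatic ring responds far more strongly than the aromatic carbon did in the earlier exchanges, all of which stayed within the scatter. Putting (prop-1-en-1-yl)carbonyl in place of hydrogen there gives a 28-fold lower number from compound 3 to compound 4 (1.44 log units; beyond the scatter) and is the only step shown that goes beyond the scatter. No measurement at hand accounts for this step.

The compounds shown leave open whether the double bond of this group matters, which a butanoyl group on the same nitrogen would test. They also leave open whether a shorter acetyl group or a methyl group there would give a similar step.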